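A few compounds are considered here, and "the series" means these few. Any claim that something is new, unique, unknown or untested is made for them only; others in the source may bear on it.

Of the compounds shown here, three sharing one core have been measured in a functional assay (Oryctolagus cuniculus) for inhibition of platelet-activating factor receptor (Cavia porcellus); a higher number here means a weaker inhibitor, a lower number a stronger inhibitor. Compound 1, `CCCCCC(=O)OCC1CN(C(=O)c2cc(OC)c(OC)c(OC)c2)CCN1C(=O)c1cc(OC)c(OC)c(OC)c1`, carries a pentyl chain on the carbonyl carbon; in this assay compound 1 gives 290 nM. Compound 2, `CCC(C)(C)NC(=O)OCC1CN(C(=O)c2cc(OC)c(OC)c(OC)c2)CCN1C(=O)c1cc(OC)c(OC)c(OC)c1`, carries a (1,1-dimethylpropyl)amino group there, and compound 2 gives 320 nM. Compound 3, `CCC(CC)NC(=O)OCC1CN(C(=O)c2cc(OC)c(OC)c(OC)c2)CCN1C(=O)c1cc(OC)c(OC)c(OC)c1`, carries a (pentan-3-yl)amino group, and compound 3 gives 130 nM, the lowest of the three numbers: a 2.2-fold lower number from compound 1 to compound 3 (0.35 log units; beyond the scatter) and a 2.5-fold lower number from compound 2 to compound 3 (0.39 log units; beyond the scatter), while a 1.1-fold higher number from compound 1 to compound 2 (0.04 log units; within the scatter).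

Compound 4 is `CCCCCN(CCCCC)C(=O)OCC1CN(C(=O)c2cc(OC)c(OC)c(OC)c2)CCN1C(=O)c1cc(OC)c(OC)c(OC)c1`. The change from compound 3 is dipentylamino in place of (pentan-3-yl)amino on a carbonyl carbon. The two steps that lead into compound 3 both bear on this: the group that enters brings two pentyl chains and no hydrogen-bond donor, so it resembles the pentyl chain of compound 1 more than the branched amino groups, and compound 1 stands a modest step above compound 3. For the measured compounds named here, a modest rise in this assay, back toward the value of compound 1, is therefore expected, though no measured pair isolates the loss of the donor. For compound 4 the estimate is 250 nM, with a range from 100 nM to 650 nM, meaning an expected step of a 1.9-fold higher number from compound 3 to compound 4 (0.28 log units; within the scatter).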

Compound 4, half-maximal inhibitory concentration: 11400 nM
Compound 4: the middle estimate sits 46-fold (1.66 log units) below what was measured; the measured number lies above the stated range.
By their numbers in this assay, from the lowest: compound 3; then compounds 1 and 2 (each within the scatter of the next); then compound 4.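

In this assay, the three earlier groups on this carbonyl carbon differ by modest steps at most, so that place looked forgiving, but dipentylamino gives an 88-fold higher number from compound 3 to compound 4 (1.94 log units; beyond the scatter) as well as a 36-fold higher number from compound 2 to compound 4 (1.55 log units; beyond the scatter) and a 39-fold higher number from compound 1 to compound 4 (1.59 log units; beyond the scatter) in the same assay. The last of these steps shows that a pentyl chain on the carbonyl carbon is compatible with a value in the range of the branched amino groups, while dipentylamino, which holds two such chains on one nitrogen, is far weaker, so the limit of what this place accepts lies somewhere between these groups. The change from compound 3 to compound 4 alters two things at once, as the heavy atoms of the group rise and its hydrogen-bond donor goes, and nothing measured here explains why the number climbs so steeply.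

The compounds shown leave open whether the second pentyl chain or the lost amide hydrogen matters more: pentylamino keeps that hydrogen with one chain, while methyl(pentyl)amino drops it with one long chain and one very short one. They also leave open how the number moves along a series of shorter twin chains, such as dipropylamino or diethylamino, on the same carbonyl carbon.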